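The compounds below may be only part of what the source reports. "The series", "measured", "known", "first", "only" and "open" are said of these compounds alone.

Three compounds have so far been run through a functional assay on MCF7 cells (Homo sapiens) for cytotoxicity, read by MTT assay, with a stated time of 72 h (a higher number here means a weaker inhibitor of growth, a lower number a stronger inhibitor of growth), and none of them has returned a measured number. Compound 1 `[SeH]c1nc2ccccc2s1` gives > 50000 nM in this assay, which is a limit of the assay. Compound 2 `N#CSc1nccc(Cl)n1` gives > 100000 nM in this assay, also a limit. Compound 3 `O=C1c2ccccc2C(=O)N1CS` gives > 100000 nM in this assay, again a limit and not a number. Two of the three values therefore sit at the limit of > 100000 nM in this assay, at which 2 of the 3 values shown sit, and one at the limit of > 50000 nM in this assay, at which 1 of the 3 values shown sits, so compound 3 stands among compounds that show no growth inhibition within the range the assay can resolve.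

The compound that follows, compound 4 `O=C1c2ccccc2C(=O)N1C[SeH]`, differs from compound 3 in a single place: one selenium atom in place of one sulfur atom, on a saturated chain carbon bound to an amide-type nitrogen in a ring. Within the data shown here, no pair of measured compounds shows what this exchange does, so the size and direction of the step cannot be read off from the data; what can be said is that compound 1, which carries a selenium atom as well, sits at a limit in this assay too. The expectation is therefore a step of an at least 2.5-fold lower number from compound 3 to compound 4 (0.39 log units; beyond the scatter), likely within the scatter, with a fair chance that the assay again reports only a limit. Compound 4 is estimated at 40000 nM, within a range from 5000 nM to 200000 nM.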

Compound 4, concentration for total growth inhibition: 8200 nM
Estimate against measurement, compound 4: 4.9-fold (0.69 log units) above, and the stated range covers the measured number.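

In this assay compound 3 gives > 100000 nM, which is a limit of the assay and not a number. Among these compounds, exchanging one sulfur atom for one selenium atom, on a saturated chain carbon bound to an amide-type nitrogen in a ring, brings an at least 12-fold lower number from compound 3 to compound 4 (1.08 log units; beyond the scatter), so this single-atom change at this position is enough to turn a compound with no number into the first compound in the set with a measured growth inhibition. The size of this step can only be given as a minimum, and the real gap may be wider, because compound 3 sits at a limit: the limit of > 100000 nM in this assay, at which 2 of the 4 values shown sit.

This one pair cannot say whether the lower number survives other changes at the same place, such as a longer chain carrying the selenium or a methyl group on the selenium atom. Nor can it say what about the exchange produces the step, or whether the same exchange would do the same on a different core.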